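This account rests on a few compounds, and the source may have more. Where it says the series, first, only, none or still open, it means among the compounds named here.

In a toxicity assay on MT4 cells (Homo sapiens) for cytotoxicity, read by MTT assay (on this read-out lower numbers stand for higher toxicity in this test and higher numbers for lower toxicity in this test), compound 1 (`Cc1cc(-c2cccc(F)c2)cc(C)c1Oc1cc(N)nc(Nc2ccc(C#N)cc2)n1`) gives 24700 nM and compound 2 (`Cc1cc(-c2cccc(C#N)c2)cc(C)c1Oc1cc(N)nc(Nc2ccc(C#N)cc2)n1`) gives 20200 nM as its number. For the measured compounds named here, these are the only two measurements so far, and compound 2 stands within the scatter of compound 1, so neither can be ranked over the other. Compound 3 (`Cc1cc(-c2ccc(C#N)c(C#N)c2)cc(C)c1Oc1cc(N)nc(Nc2ccc(C#N)cc2)n1`) has not yet been measured. It is compound 2 with cyano in place of hydrogen on an aromatic carbon, ortho to a cyano group, which turns 3-cyanophenyl into 3,4-dicyanophenyl (cyano in place of hydrogen on an aromatic carbon). Going by the values given here, only one measured step bears on this change: cyano in place of fluoro on an aromatic carbon gave a 1.2-fold lower number from compound 1 to compound 2 (0.09 log units; within the scatter) and so stayed within the scatter. That step swaps one group for another, whereas compound 3 gains a group, so it is only a loose guide. Among the compounds with values here, no measured pair shows a second cyano group being added. With that caution, the expected change is a 1.0-fold lower number from compound 2 to compound 3 (0.00 log units; within the scatter) and no step beyond the scatter. For compound 3 the estimated value is 20000 nM with 9000 nM and 42000 nM as the expected ends of its range.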

Compound 3, half-maximal cytotoxic concentration: 17600 nM
Compound 3: middle estimate off by 1.1-fold (0.06 log units), on the high side, and the stated range covers the measured number.
By their numbers in this assay, from the lowest: compounds 3, 2 and 1 (each within the scatter of the next).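

In this assay, for the compounds shown here, a second cyano group on the aromatic carbon ortho to a cyano group and para to a large group gives a 1.1-fold lower number from compound 2 to compound 3 (0.06 log units; within the scatter), so this is the first added group, and the step stays within the scatter. The larger change from 3-fluorophenyl to 3,4-dicyanophenyl gives a 1.4-fold lower number from compound 1 to compound 3 (0.15 log units; within the scatter), also within the scatter, so the three compounds cannot be ranked against each other on this read-out, even across the two ends of the set. No measurement shown here offers an explanation for how close these numbers lie.

From the compounds shown here alone, all three compounds carry only fluoro or cyano groups on this ring, so it remains open whether an amine, a carboxylic acid or a longer chain at the same position would produce a step beyond the scatter. Going by these compounds, it is also open whether the move to 3,4-dicyanophenyl would stay this small on a different core, since every compound here shares the same one.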